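The compounds below may be only part of what the source reports. "The series", "measured", "known", "first", "only" and "open" are said of these compounds alone.

Compound 1, `CCN(CC)Cc1cc(Br)c(S(C)(=O)=O)cc1C(=O)N=C(N)N`: 9500 nM
Compound 2, `Cc1cc(-c2ccc(Cl)cc2Cl)c(S(C)(=O)=O)cc1C(=O)N=C(N)N`: 42 nM

In a functional assay for inhibition of sodium/hydrogen exchanger (Oryctolagus cuniculus) (a lower number here means a stronger inhibitor, a higher number a weaker inhibitor), compound 2 holds the lower of the two numbers; compound 1 sits far above it, and that gap lies beyond the scatter. Compound 3, `CCOc1cc(C)c(C(=O)N=C(N)N)cc1S(C)(=O)=O`, is not yet measured. It differs from compound 2 as follows: ethoxy in place of 2,4-dichlorophenyl on an aromatic carbon. Among the measured compounds shown here, no measured pair covers this change on its own, since the two measured compounds differ in several places at once. A clear weakening is expected, a rise in the number well beyond the scatter, as an estimated step of a 29-fold higher number from compound 2 to compound 3 (1.46 log units; beyond the scatter). For compound 3 the estimate is 1200 nM, within a range from 200 nM to 6000 nM.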

Compound 3, half-maximal inhibitory concentration: 19 nM
For compound 3 the middle estimate is 63-fold (1.80 log units) above the measured one; measured number outside the range, below it.
By their numbers in this assay, from the lowest: compound 3; then compound 2; then compound 1.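

In this assay, the aromatic carbon ortho to a methylsulfonyl group does not depend on the 2,4-dichlorophenyl, since ethoxy in its place gives a 2.2-fold lower number from compound 2 to compound 3 (0.34 log units; beyond the scatter) as a modest gain beyond the scatter. This position therefore accepts a chain with no ring, 3 heavy atoms in place of 8. Nothing available explains this step. Going by these compounds, whether the gain follows the ether oxygen or the smaller group stays open. Methoxy, butoxy or a diethylamino group on this carbon would help separate the two.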